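This account rests on a few compounds, and the source may have more. Where it says the series, first, only, none or still open, it means among the compounds named here.

Working notes on the series. For the measured compounds named here, compound 1 `O=C(c1ccc(NCc2cncn2Cc2ccc(-c3ccccc3)cc2)cc1-c1ccccc1)N1CCCCC1` is the only member with a reported outcome in a toxicity assay on NIH3T3 cells (Mus musculus) for cytotoxicity, read by resazurin assay; on this read-out lower numbers stand for an effect already at smaller amounts and higher numbers for an effect only at larger amounts of compound. In this assay compound 1 gives > 1000 nM, which is a limit of the assay rather than a number. That is the situation summarised by the limit of > 1000 nM in this assay, at which 1 of the 2 values shown sits. Compound 2 `COC(=O)c1ccc(NCc2cncn2Cc2ccccc2F)cc1-c1ccccc1` shares the core with compound 1 but differs in two places; in this assay compound 2 gives "not determined" (no result reported), so no single number stands for it and its place in the series rests on no measurement of its own. Compound 3 `COC(=O)c1ccc(NCc2cncn2Cc2ccc(C#N)cc2)cc1-c1ccccc1` is reached from compound 2 by 4-cyanophenyl in place of 2-fluorophenyl on a saturated chain carbon bound to an aromatic nitrogen. No measured step in this assay involves either compound, so for the step from compound 2 to compound 3 no size beyond the scatter and no direction can be expected from what is shown. For compound 3 the expected outcome in this assay is estimated at 3000 nM, with a likely range of 800 nM to 15000 nM.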

Compound 3, half-maximal effective concentration: > 10000 nM
Compound 3 gave a limit, no number (the forecaster's own chance of this, stated with the estimate: 70%); middle value at least 3.3-fold (0.52 log units) from the limit.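

In this assay compound 3 gives > 10000 nM, which is a limit and not a number. For the compounds shown here, compound 2 has no single number either, so no step between compound 2 and compound 3 can be read. The compounds shown leave open at what concentration any member of the series becomes cytotoxic.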